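Exchanging a tetrazole for a triazole in adenosine receptor binders

The source may report more compounds than this note shows. Statements on the series, on what has been measured and on what is new or still open speak of the compounds shown alone.

In an assay on CHO cells for displacement of a labelled ligand from adenosine receptor A3 (Homo sapiens), read by scintillation counting, with a stated time of 120 min, tested at 1 uM (on this read-out lower numbers stand for less inhibition and higher numbers for more inhibition at the one concentration tested (going by the name of the read-out)), compound 1 `N#Cc1c(N)nc(SCc2ncn[nH]2)c(C#N)c1-c1ccc(OCC2CC2)cc1` gives 1%, and compound 2 `N#Cc1c(N)nc(SCc2nnn[nH]2)c(C#N)c1-c1ccc(OCC2CC2)cc1` gives 1%. Compound 3 `CC(C)COc1ccc(-c2c(C#N)c(N)nc(SCC(N)=O)c2C#N)cc1` gives 9%. Compound 2 thus stands level with compound 1, the two together being the lowest of the three numbers, and its gap to compound 3 lies within the scatter. For the measured compounds named here, compound 4 `N#Cc1c(N)nc(SCn2cncn2)c(C#N)c1-c1ccc(OCC2CC2)cc1` differs from compound 2 in one place: 1H-1,2,4-triazol-1-yl in place of 1H-tetrazol-5-yl on a saturated chain carbon bound to a sulfur The only measured step that bears on this exchange of one five-membered aromatic ring for another is no change at the digits printed from compound 1 to compound 2 (within the scatter). Going by the values given here, nothing among the measured compounds points to a step beyond the scatter from such an exchange. Compound 4 is therefore expected to give 3%, within a range of -6% to 14%. The step of a number 2 percentage points higher from compound 2 to compound 4 (within the scatter) that this estimate means is expected to stay within the scatter.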

Compound 4, a percentage reported as inhibition, at one concentration (the size of the read-out at that concentration, not a potency): 1%
Compound 4: middle estimate off by 2 percentage points, on the high side; the range from low to high includes it.
By their numbers in this assay, from the lowest: compounds 1, 2, 4 and 3 (each within the scatter of the next).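

With the 1H-1,2,4-triazol-1-yl group in this assay, the read-out shows no change at the digits printed from compound 2 to compound 4 (within the scatter) and no change at the digits printed from compound 1 to compound 4 (within the scatter). On the saturated chain carbon bound to a sulfur, neither the loss of the ring's hydrogen-bond donor nor the change of ring brings a step beyond the scatter, though compounds this low leave little room for any further drop to show. No evidence on the reason for this is available.

On these data alone, whether another group at this place would raise the number remains open, for instance a carboxylic acid or an amine, or a longer chain carrying the same ring.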